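The source may hold more compounds than are shown below. What is called first, only, known or untested is meant among the compounds shown, and "the series" means these compounds.

Measured so far:
- Compound 1 `CC1=CC[C@H](C(C)C)c2cc(C)c(OC(=O)Nc3ccccc3)cc21`: 100%
- Compound 2 `Cc1cc2c(C(C)C)ccc(C)c2cc1OC(=O)c1ccc(C(F)(F)F)cc1`: 28.7%

In a functional assay on SK-LU-1 cells (Homo sapiens) for antiproliferative activity, read by sulforhodamine B assay, with a stated time of 48 h, tested at 50 uM (on this read-out higher numbers stand for more inhibition at the one concentration tested (going by the name of the read-out) and lower numbers for less inhibition), compound 1 gives 100%, the highest of the two numbers; compound 2 gives 28.7%, which lies far lower, beyond the scatter. The two compounds differ in more than one place, so their gap is simply what the two values show.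

Compound 3 `CC1=CC[C@H](C(C)C)c2cc(C)c(OC(=O)c3ccc(Cl)cc3)cc21` keeps the core of compound 1 and changes only the group on the carbonyl carbon: 4-chlorophenyl in place of anilino on a carbonyl carbon. Among the measured compounds shown here, no measured pair reports this change alone. Compound 2, the only other ester here, sits much lower than compound 1 in this assay, though its core also differs, so the comparison is indirect. The expected step of a number 40 percentage points lower from compound 1 to compound 3 (beyond the scatter) is downward and likely beyond the scatter. Compound 3 is therefore estimated at 60%, within a range of 25% to 95%.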

Compound 3, a percentage reported as inhibition, at one concentration (the size of the read-out at that concentration, not a potency): 17.4%
Compound 3: middle estimate off by 42.6 percentage points, on the high side, outside the stated range (below it).
By their numbers in this assay, from the lowest: compound 3; then compound 2; then compound 1.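

In this assay, with the core of compound 1 held fixed, 4-chlorophenyl in place of anilino on a carbonyl carbon brings a number 82.6 percentage points lower from compound 1 to compound 3 (beyond the scatter), so the group at this one position moves the read-out far on its own, which the earlier pair, differing in more than one place, could not show. The two groups match in heavy-atom count and in their aromatic ring, but the anilino group has a hydrogen-bond donor and the 4-chlorophenyl group has none. No measurement here explains the step.

Going by these compounds, whether the drop follows the loss of the nitrogen or the arrival of the chlorine stays open, since both change at once. Also open, on these data alone, is where an unsubstituted phenyl or a cyclohexylamino group on this carbonyl carbon would fall relative to compound 1 and compound 3.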